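The source may hold more compounds than are shown below. What is called first, only, known or untested is meant among the compounds shown, and "the series" means these compounds.

Measured compounds:
Compound 1 `[O-][n+]1nc(NCOC2CCCCC2)[n+]([O-])c2ccccc21` — in a functional assay on K562 cells (Homo sapiens) for cytotoxicity, read by MTT assay, with a stated time of 72 h (on this read-out lower numbers stand for stronger inhibition and higher numbers for weaker inhibition), compound 1 gives 10800 nM.
Compound 2 `O=[N+]([O-])c1cccc(COCNc2n[n+]([O-])c3ccccc3[n+]2[O-])c1` — in this assay compound 2 gives 5650 nM.

Of the compounds shown here, two share a core and have been measured so far. Compound 1 has the higher of the two numbers, but the gap to compound 2 lies within the scatter of repeated measurements, so the two values cannot be told apart and neither compound can be called the more active one.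

Compound 3 `CCCCCOCNc1n[n+]([O-])c2ccccc2[n+]1[O-]` has not been measured. It differs from compound 1 in one place: pentyl in place of cyclohexyl on an oxygen on a saturated carbon. Among the measured compounds shown here, no step between two measured compounds that differ in only one place is available here, so nothing is known yet about how large a change of this kind is worth in this assay. Given that the two measured values sit within the scatter of each other, the step of a 1.2-fold lower number from compound 1 to compound 3 (0.08 log units; within the scatter) is expected to stay within the scatter, with no clear direction. Compound 3 is therefore expected to give 9000 nM, with a range from 3500 nM to 25000 nM.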

Compound 3, half-maximal inhibitory concentration: 14500 nM
For compound 3 the middle estimate is 1.6-fold (0.21 log units) below the measured one; measured number inside the range.
By their numbers in this assay, from the lowest: compounds 2, 1 and 3 (each within the scatter of the next, the first and the last beyond it).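

Among the compounds shown here, this is the first step between two measured compounds that differ in only one place: in this assay, pentyl in place of cyclohexyl on an oxygen on a saturated carbon gives a 1.3-fold higher number from compound 1 to compound 3 (0.13 log units; within the scatter). At this position, then, a six-membered ring of carbon and an open pentyl chain cannot be told apart, so for this pair the ring is not needed to keep the number where it stands. No measurement of any property of these two groups is available to bear on this result.

What the compounds shown leave open is whether any group at this place can move the number beyond the scatter, for example a much longer chain, an amine or a carboxylic acid on the end of the chain. Since this single step compares two groups made only of carbon and hydrogen, it also leaves open whether the same tolerance would hold for groups of a different kind, or whether the same swap would read alike in any other test.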